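Stretching the Side Chain Toward a Carboxylic Acid

The source may hold more compounds than are shown below. What is called first, only, known or untested is meant among the compounds shown, and "the series" means these compounds.

All three measured compounds share one core and differ only in the chain on the aromatic oxygen. In a functional assay on mitochondria (Cricetulus griseus) for inhibition of Monoamine oxidase (Homo sapiens), tested at 3 uM (on this read-out higher numbers stand for a stronger effect at the one concentration tested and lower numbers for a weaker effect), compound 1 `O=c1c(-c2ccc(O)cc2)coc2cc(OCCCCBr)ccc12` gives 84.7%, compound 2 `O=c1c(-c2ccc(O)cc2)coc2cc(OCCCBr)ccc12` gives 90.8%, and compound 3 `O=c1c(-c2ccc(O)cc2)coc2cc(OCC(O)CO)ccc12` gives 85%. Compound 3 thus sits second highest of the three numbers, with compound 1 nearest and compound 2 furthest, every gap within the scatter. Compound 4 `O=C(O)CCCCCCOc1ccc2c(=O)c(-c3ccc(O)cc3)coc2c1` carries the change (5-carboxypentyl in place of 1,2-dihydroxyethyl on a saturated chain carbon bound to an oxygen on an aromatic ring). Earlier swaps at the same place, a number 0.3 percentage points higher from compound 1 to compound 3 (within the scatter) and a number 5.8 percentage points lower from compound 2 to compound 3 (within the scatter), stayed within the scatter, as did the chain shortening a number 6.1 percentage points higher from compound 1 to compound 2 (within the scatter). With no step beyond the scatter so far, the step of a number 1 percentage points lower from compound 3 to compound 4 (within the scatter) is expected to stay within the scatter. Compound 4 is therefore estimated at 84%, between 70% and 95%.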

Compound 4, a percentage reported as inhibition, at one concentration (the size of the read-out at that concentration, not a potency): 87.4%
Estimate against measurement, compound 4: 3.4 percentage points below; measured number inside the range.
By their numbers in this assay, from the lowest: compounds 1, 3, 4 and 2 (each within the scatter of the next).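

The 5-carboxypentyl group, with 8 heavy atoms against 4 in 1,2-dihydroxyethyl, leaves this assay within the scatter at every comparison: a number 2.4 percentage points higher from compound 3 to compound 4 (within the scatter), a number 3.4 percentage points lower from compound 2 to compound 4 (within the scatter) and a number 2.7 percentage points higher from compound 1 to compound 4 (within the scatter). Across these four compounds, then, a chain ending in a carboxylic acid, a bromo or two hydroxyl groups gives no step beyond the scatter. Nothing available explains this sameness.

On these data alone, whether a chain ending in an amine would also stay within the scatter remains open. A single tested concentration also leaves open whether any of these compounds would have a stronger or weaker effect than the others at a different concentration.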